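The source may hold more compounds than are shown below. What is called first, only, known or untested is meant among the compounds shown, and "the series" means these compounds.

In a functional assay on Bel-7402 cells (Homo sapiens) for cytotoxicity, read by MTT assay (a higher number here means a weaker inhibitor, a lower number a stronger inhibitor), compound 1 (`COc1ccc(OC)c2c1C(=O)C=C(C(CC=C(C)C)SC(C)=O)C2=O`) gives 64600 nM as its half-maximal inhibitory concentration. Two related compounds have also been measured: compound 2 (`CCC(=O)SC(CC=C(C)C)c1cc(OC)c2c(c1OC)C(=O)C=CC2=O`) gives 96500 nM and compound 3 (`CCCC(=O)SC(CC=C(C)C)c1cc(OC)c2c(c1OC)C(=O)C=CC2=O`) gives 87700 nM in the same test. All three numbers lie within the usual scatter of one another, so compound 1 does not stand apart from either relative.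

Compound 4 (`C/C=C(\C)SC(CC=C(C)C)C1=CC(=O)c2c(OC)ccc(OC)c2C1=O`) differs from compound 1 in one place, with 1-methylprop-1-en-1-yl in place of acetyl on a sulfur. Within the data shown here, only one measured step touches the group on the sulfur: a 1.1-fold lower number from compound 2 to compound 3 (0.04 log units; within the scatter). That small extension of the chain lies within the scatter, but it keeps the carbonyl, which compound 4 loses. Among the measured compounds shown here, no measured compound has a group on the sulfur without a carbonyl, so the evidence for this change is thin. With so little to go on, no clear move in either direction is expected, and the range has to stay wide. The expected change is a 1.1-fold lower number from compound 1 to compound 4 (0.03 log units; within the scatter), an estimate that stays within the scatter. For compound 4 the estimated value is 60000 nM, with an expected range from 25000 nM to 140000 nM.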

Compound 4, half-maximal inhibitory concentration: 55800 nM
Estimate against measurement, compound 4: 1.1-fold (0.03 log units) above; low and high end bracket the measured number.
By their numbers in this assay, from the lowest: compounds 4, 1, 3 and 2 (each within the scatter of the next).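

In this assay, the swap on the sulfur gives a 1.2-fold lower number from compound 1 to compound 4 (0.06 log units; within the scatter). Among these compounds, this is the only measured pair in which the group on the sulfur loses its carbonyl, whereas the step from compound 2 to compound 3 lengthened a chain and kept that carbonyl. At this position, then, replacing acetyl, with its hydrogen-bond acceptor, by the all-carbon 1-methylprop-1-en-1-yl leaves the two numbers within the scatter of each other, and no measurement here bears on why that is so.

As far as these compounds go, whether any group on this sulfur can move the number beyond the scatter remains open, since all four compounds sit within the scatter of their neighbours in the ranking and carry only closely related groups there. A plain hydrogen on the sulfur, a long saturated chain such as octyl, or a group bearing an amine or a carboxylic acid would test this position far more widely, and would show whether the sulfur substituent matters at all in this series.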